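This account rests on a few compounds, and the source may have more. Where it says the series, first, only, none or still open, it means among the compounds named here.

Compound 1 `CCC(C)NC(=C\C(=O)/C=C/c1ccc(O)c(OC)c1)/C=C/c1ccc(O)c(OC)c1` in an ADME assay on Caco-2 cells (Homo sapiens) for inhibition, read by sulforhodamine B assay, with a stated time of 72 h (a higher number here means a weaker inhibitor, a lower number a stronger inhibitor), gives > 25000 nM, which is a limit of the assay and not a number. Compound 2 `COc1cc(/C=C/C(=O)/C=C(/C=C/c2ccc(O)c(OC)c2)NC2CCCCC2)ccc1O` in this assay gives > 25000 nM, again only a limit. The change from compound 1 to compound 2 is cyclohexyl in place of sec-butyl on an amine nitrogen, and the step that the two limits leave unreadable from compound 1 to compound 2. Compound 3 `CCC(C)NC(=C\C(=O)/C=C/c1ccc(O)cc1)/C=C/c1ccc(O)cc1` in this assay gives > 25000 nM, also a limit. All three values sit at the limit of > 25000 nM in this assay, at which 3 of the 3 values shown sit. The difference between the cores of compound 3 and compound 1 is not broken down here. Compound 4 `O=C(/C=C(/C=C/c1ccc(O)cc1)NC1CCCCC1)/C=C/c1ccc(O)cc1` is not yet measured in this assay; it differs from compound 3 by cyclohexyl in place of sec-butyl on an amine nitrogen, the same change as from compound 1 to compound 2, at the same place. The expected step is a step that the limit leaves unreadable from compound 3 to compound 4, resting on compound 1 and compound 2 both sitting at the limit of > 25000 nM in this assay, at which 3 of the 3 values shown sit. Compound 4 is therefore expected at 50000 nM.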

Compound 4, half-maximal inhibitory concentration: > 25000 nM
Compound 4: only a limit was reported (the forecaster's own chance of this, stated with the estimate: 85%); the middle value does not contradict the limit.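

No step can be read from compound 3 to compound 4, both values being limits of the assay and not numbers: the limit of > 25000 nM in this assay, at which 4 of the 4 values shown sit.

The compounds shown leave open how strongly any of them inhibits in this assay, and whether cyclohexyl in place of sec-butyl changes that.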